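A few compounds are considered here, and "the series" means these few. Any claim that something is new, unique, unknown or untested is made for them only; others in the source may bear on it.

Measured compounds:

Compound 1 `CC(C)(C)c1ccc(C(=O)/C=C/c2ccco2)cc1`: in an ADME assay on THP-1 cells (Homo sapiens) for cytotoxicity, read by resazurin assay, with a stated time of 72 h (on this read-out lower numbers stand for higher toxicity in this test and higher numbers for lower toxicity in this test), compound 1 reaches only the limit of the assay, > 50000 nM.

Compound 2 `CSc1ccc(C(=O)/C=C/c2ccc([N+](=O)[O-])o2)cc1`: in this assay compound 2 gives 13100 nM.

Compound 3 `O=C(/C=C/c1ccco1)c1ccc(N2CCCCC2)cc1`: in this assay compound 3 reaches only the limit of the assay, > 50000 nM.

Compound 3 therefore stands at a limit rather than at a number, a position it shares with compound 1, as shown by the limit of > 50000 nM in this assay, at which 2 of the 3 values shown sit. Among the measured compounds shown here, compound 2 is the one measured compound that registers a number. The change on the way to compound 4 `CSc1ccc(C(=O)/C=C/c2ccco2)cc1` is methylsulfanyl in place of piperidin-1-yl on an aromatic carbon. For the measured compounds named here, the only measured step, a step that the two limits leave unreadable from compound 1 to compound 3, concerns the same aromatic carbon, but both of its ends sit at the limit, so it gives no size to lean on. Compound 2 carries the methylsulfanyl group that enters here, yet it differs from compound 4 in a second place as well, so its value alone cannot fix the step. No readable precedent exists for this change, so the step of an at least 1.2-fold lower number from compound 3 to compound 4 (0.09 log units; that floor lies within the scatter) is an expectation of a small move toward a number, with wide uncertainty. Compound 4 is estimated at 40000 nM, within a range from 15000 nM to 100000 nM.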

Compound 4, half-maximal cytotoxic concentration: > 50000 nM
Compound 4: a limit, no number (the forecaster's own chance of this, stated with the estimate: 55%); middle value at least 1.2-fold (0.09 log units) away from the limit.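

Hydrogen in place of nitro on an aromatic carbon gives an at least 3.8-fold higher number from compound 2 to compound 4 (0.58 log units; beyond the scatter), the first step in this set with a readable size, and it runs toward lower toxicity in this assay. Compound 4 gives only a limit of the assay, > 50000 nM, so among the compounds shown, methylsulfanyl without the nitro group does not bring the read-out to a number, and the one number seen belongs to the compound that carries both groups. The steps that join compound 4 to compound 1 and to compound 3 cannot be read, with both ends of each resting on the same limit: the limit of > 50000 nM in this assay, at which 3 of the 4 values shown sit.

As far as these compounds go, how far the tert-butyl, piperidin-1-yl and methylsulfanyl compounds differ from one another remains unknown, since all three share that limit, and it is also open whether the nitro group would shift the read-out to the same extent alongside tert-butyl or piperidin-1-yl as it does alongside methylsulfanyl. Equally open, from the compounds shown here alone, is what a carboxylic acid or a primary amine would do on the aromatic carbon that holds methylsulfanyl in compound 4.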